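The source may report more compounds than this note shows. Statements on the series, on what has been measured and on what is new or still open speak of the compounds shown alone.

- Compound 1 `COc1ccc(NC(=S)NCCNS(=O)(=O)c2sccc2-c2ccc(C)cc2Oc2ccc(O)c(O)c2)cc1`: 8300 nM
- Compound 2 `O=[N+]([O-])c1cccc(NC(=S)NCCNS(=O)(=O)c2ccc(-c3ccccc3OCc3ccccc3)s2)c1`: 11600 nM
- Compound 3 `Cc1ccc(-c2ccsc2S(=O)(=O)NCCNC(=S)Nc2ccc([N+](=O)[O-])cc2)c(Oc2ccc(O)c(O)c2)c1`: 5100 nM

In a functional assay on RS4-11 cells (Homo sapiens) for inhibition, read by CCK-8 assay, with a stated time of 48 h (a lower number here means a stronger inhibitor, a higher number a weaker inhibitor), compound 3 at 5100 nM sits within the scatter of compound 1 and has a lower number than compound 2. Compound 4 `Cc1ccc(-c2ccsc2S(=O)(=O)NCCNC(=S)Nc2cccc([N+](=O)[O-])c2)c(Oc2ccc(O)c(O)c2)c1` differs from compound 3 in one place, with 3-nitrophenyl in place of 4-nitrophenyl on an amide-type nitrogen. For the measured compounds named here, the only measured step that bears on this is a 1.6-fold lower number from compound 1 to compound 3 (0.21 log units; within the scatter), with nitro in place of methoxy on an aromatic carbon, and it stays within the scatter. Going by the values given here, no measured pair isolates the change of nitro position. Compound 2 carries 3-nitrophenyl, but on a different core. No step beyond the scatter is therefore expected, and the estimated step is a 1.1-fold higher number from compound 3 to compound 4 (0.03 log units; within the scatter). Compound 4 is expected at 5500 nM, with an estimated range of 2800 nM to 11000 nM.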

Compound 4, half-maximal inhibitory concentration: 6100 nM
Beside the measured number, compound 4's estimate is 1.1-fold (0.04 log units) below it; the range from low to high includes it.
By their numbers in this assay, from the lowest: compounds 3, 4, 1 and 2 (each within the scatter of the next, the first and the last beyond it).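

In this assay the step from 4-nitrophenyl to 3-nitrophenyl is a 1.2-fold higher number from compound 3 to compound 4 (0.08 log units; within the scatter) and so the two nitro isomers on the amide-type nitrogen cannot be told apart on this core. The step from the methoxy compound is a 1.4-fold lower number from compound 1 to compound 4 (0.13 log units; within the scatter) and so none of the three aryl groups on this core stands apart from the others. Nothing measured here accounts for this result. The compounds shown leave open whether an amine or a carboxylic acid on that phenyl ring, or a longer chain in its place, would give a step beyond the scatter.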